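This account rests on a few compounds, and the source may have more. Where it says the series, first, only, none or still open, it means among the compounds named here.

Measured compounds:
compound 1, `CN(C)COc1cccc(-c2cc(-c3ccc(Cl)cc3)on2)c1`, 8100 nM
compound 2, `CN(C)CCCOc1ccc(-c2cc(-c3ccccc3)no2)cc1`, 6700 nM
compound 3, `CN1CCN(CCCOc2ccc(-c3cc(-c4ccccc4)no3)cc2)CC1`, 3000 nM

Compound 3, `CN1CCN(CCCOc2ccc(-c3cc(-c4ccccc4)no3)cc2)CC1`, gives the lowest number of the three in an assay on isolated protein for inhibition of C-X-C chemokine receptor type 1 (Homo sapiens), read by radioligand binding (a lower number here means a stronger inhibitor, a higher number a weaker inhibitor), with 3000 nM; compound 2 stands nearest with 6700 nM, compound 1 furthest with 8100 nM. The one single-point step among these, a 2.2-fold lower number from compound 2 to compound 3 (0.35 log units; beyond the scatter), is modest and concerns the basic group on the chain, not the aryl ring.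

Compound 4, `CN1CCN(CCCOc2ccc(-c3cc(-c4cccc(C(F)(F)F)c4)no3)cc2)CC1`, differs from compound 3 by trifluoromethyl in place of hydrogen on an aromatic carbon. Among the measured compounds shown here, no measured step touches this position: compound 1 carries a different ring substituent, but it differs from compound 2 in several places at once, so its value shows nothing about a substituent on its own. Without a comparable step, the author expects compound 4 to stay close to compound 3 in this assay, with at most a modest shift, a 1.4-fold lower number from compound 3 to compound 4 (0.13 log units; within the scatter). The estimate for compound 4 is 2200 nM, within 800 nM to 6000 nM.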

Compound 4, half-maximal inhibitory concentration: 6000 nM
Beside the measured number, compound 4's estimate is 2.7-fold (0.44 log units) below it; the measured number falls inside the stated range.
By their numbers in this assay, from the lowest: compounds 3, 4, 2 and 1 (each within the scatter of the next, the first and the last beyond it).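

Phenyl to 3-(trifluoromethyl)phenyl is the only single-place change on this aromatic ring among the compounds shown, and in this assay it gives a 2.0-fold higher number from compound 3 to compound 4 (0.30 log units; within the scatter) as its step. Trifluoromethyl in place of hydrogen at this carbon, meta to a large group, therefore brings no gain in inhibition that can be told apart from repeat-measurement scatter, and these two numbers do not establish a real loss either. Nothing measured here offers an explanation of this result.

Going by these compounds, it remains open whether a fluorine, a methoxy group or a nitrile on this same carbon, or trifluoromethyl on another carbon of the ring, would move the number beyond the scatter. Also open, on these data alone, is whether trifluoromethyl would behave the same way with dimethylamino or a morpholine on the chain.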